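This account rests on a few compounds, and the source may have more. Where it says the series, first, only, none or still open, it means among the compounds named here.

Measured so far:
- compound 1, `O=C(Nc1ccccc1)c1c(NO)cc(-c2ccccc2)oc1=O`: 11600 nM in an ADME assay on Huh-7 cells (Homo sapiens) for cytotoxicity, read by a luciferase reporter and WST assay, with a stated time of 3 days; a lower number here means that less compound is tolerated, a higher number that more compound is tolerated
- compound 2, `Cc1ccc(NC(=O)c2c(NO)cc(-c3ccc(F)cc3)oc2=O)cc1`: compound 2 reaches only the limit > 20000 nM
- compound 3, `O=C(NCCO)c1c(NO)cc(-c2ccc(F)cc2)oc1=O`: compound 3 likewise stops at the limit > 20000 nM

Going by the values given here, compound 1 holds the only true number in this assay; the other two values are limits, and the limit of > 20000 nM in this assay, at which 2 of the 3 values shown sit, is where both sit. Among the compounds with values here, the single step among the measured compounds, a step that the two limits leave unreadable from compound 2 to compound 3, cannot be read for size since both ends are limits, so it gives no measure of how far a change on the amide-type nitrogen moves cytotoxicity here.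

Compound 4 is `O=C(NCc1ccccc1)c1c(NO)cc(-c2ccccc2)oc1=O`, not yet measured. It differs from compound 1 by benzyl in place of phenyl on an amide-type nitrogen.

Within the data shown here, no measured step bears directly on this change. With compound 1 at 11600 nM, the expectation for the step is small, a 1.2-fold higher number from compound 1 to compound 4 (0.08 log units; within the scatter), direction uncertain and within scatter. Compound 4 is therefore estimated at 14000 nM, with a range from 6000 nM to 40000 nM, and a fair chance that only a limit is reported.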

Compound 4, half-maximal cytotoxic concentration: > 20000 nM
Compound 4 ended at the assay's limit; the forecaster's own chance of this, stated with the estimate: 40%; middle value at least 1.4-fold (0.15 log units) away from the limit.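

Benzyl in place of phenyl on an amide-type nitrogen gives, in this assay, an at least 1.7-fold higher number from compound 1 to compound 4 (0.23 log units; that floor lies within the scatter). Unlike the earlier step between two limits, which cannot be read, this step has a true number at one end, so it offers the first floor for a change at this position, though that floor does not clear the scatter. The anilino to benzylamino change therefore shows no tolerated concentration falling, and the series now reads mostly as limits: the limit of > 20000 nM in this assay, at which 3 of the 4 values shown sit.

As far as these compounds go, the true size of the step stays open, with only a limit at the compound 4 end. Also open, from the compounds shown here alone, is whether a longer chain on the same nitrogen, such as 2-phenylethyl, or a carboxylic acid or an amine on the benzyl ring, would give a number inside the assay's range.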